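Branching the Ester Chain of Compound 1

A few compounds are considered here, and "the series" means these few. Any claim that something is new, unique, unknown or untested is made for them only; others in the source may bear on it.

Compound 1: `CCCCOC(=O)C(O)Cn1cnc2c(N)ncnc21` gives 400 ug/mL in a functional assay on HeLa cells (Homo sapiens) for cytotoxicity; on this read-out higher numbers stand for lower toxicity in this test and lower numbers for higher toxicity in this test.
Compound 2: `COC(=O)C(O)Cn1cnc2c(N)ncnc21` gives > 400 ug/mL in this assay, a limit of the assay and not a number.
Compound 3: `CC(C)CCOC(=O)C(O)Cn1cnc2c(N)ncnc21` gives 400 ug/mL in this assay.

Compound 1 stands level with compound 3 at the digits shown; the only other value, that of compound 2, is a limit. Changing the ester chain has so far left the read-out where it was: no change at the digits printed from compound 1 to compound 3 (within the scatter), and a number no lower from compound 1 to compound 2 (the limit leaves the size open), while a number no higher from compound 2 to compound 3 (the limit leaves the size open). One of the three values sits at the limit of > 400 ug/mL in this assay, at which 1 of the 3 values shown sits, so the room above compound 1 is narrow.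

Compound 4 is `CCC(C)OC(=O)C(O)Cn1cnc2c(N)ncnc21`. It differs from compound 1 only in the ester chain: sec-butyl in place of butyl on an oxygen next to a carbonyl group. The steps to compound 2 and compound 3 bear on this change and were within the scatter or open limits, so the account expects no step beyond the scatter in this assay. For compound 4 the account estimates 400 ug/mL, between 200 ug/mL and 800 ug/mL, a step of no change at the digits printed from compound 1 to compound 4 (within the scatter); the measured value follows.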

Compound 4, minimum cytotoxic concentration: > 400 ug/mL
Compound 4 gave a limit, no number; the forecaster's own chance of this, stated with the estimate: 40%; the middle value sits exactly at the limit.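

The value of compound 4 in this assay is a limit of the assay and not a number. On the oxygen next to the carbonyl group, sec-butyl in place of butyl gives a number no lower from compound 1 to compound 4 (the limit leaves the size open), and sec-butyl in place of isopentyl gives a number no lower from compound 3 to compound 4 (the limit leaves the size open), so one branched chain, isopentyl in compound 3, stays level with compound 1 while the other, sec-butyl, reaches the limit. The step between compound 2 and compound 4 cannot be read, and no size can be given for this change: the limit of > 400 ug/mL in this assay, at which 2 of the 4 values shown sit.

Going by these compounds, how far compound 4 lies past the limit stays open, and so does any difference between sec-butyl and methyl. The compounds shown also do not tell how a tert-butyl ester, a longer chain or an amide in place of the ester would read in this assay.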